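From dimethylamino to methoxy: a half-life still open

This account rests on a few compounds, and the source may have more. Where it says the series, first, only, none or still open, it means among the compounds named here.

In an ADME assay for pharmacokinetics, read by LC-MS, in phosphate buffer, with a stated time of 120 min, at pH 7.4, tested at 1 uM, in the presence of a further agent that is not named here (a lower number here means that the compound disappears faster, a higher number that the compound lasts longer), compound 1 (`C=C(C(=O)Nc1ccccc1)C(F)(F)F`) gives 0.25 h as its half-life. Compound 2 (`C=C(CN(C)C)C(=O)Nc1ccccc1`) gives < 0.0334 h as its half-life, and this value is a limit of this assay and not a number. Going by the values given here, the one measured step that bears on what follows is an at least 7.4-fold lower number from compound 1 to compound 2 (0.87 log units; beyond the scatter) in which (dimethylamino)methyl takes the place of trifluoromethyl on a double-bonded chain carbon bound to a carbonyl carbon.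

Compound 3 (`C=C(COC)C(=O)Nc1ccccc1`) carries methoxy in place of dimethylamino on a saturated chain carbon bound to a double-bonded chain carbon. The same change, cut one bond further out, reads (dimethylamino)methyl to methoxymethyl. Among the compounds with values here, with the step of an at least 7.4-fold lower number from compound 1 to compound 2 (0.87 log units; beyond the scatter) as the only guide, a modest to moderate rise in half-life is expected, toward compound 1 at 0.25 h without clearly passing it. The estimate therefore means an at least 3.5-fold higher number from compound 2 to compound 3 (0.55 log units; beyond the scatter) as the expected step, in the direction of a longer half-life. For compound 3 the expected half-life is 0.12 h with an estimated range from 0.04 h to 0.5 h in this assay as the setting.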

Compound 3, half-life: 4.02 h
For compound 3 the middle estimate is 34-fold (1.53 log units) below the measured one; measured number outside the range, above it.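

At this place, on a saturated chain carbon bound to a double-bonded chain carbon, methoxy in place of dimethylamino gives an at least 120-fold higher number from compound 2 to compound 3 (2.08 log units; beyond the scatter) in this assay, which shows that this one change on the shared core can separate a compound that disappears quickly from one that lasts for hours. The comparison with trifluoromethyl also changes: methoxymethyl in place of trifluoromethyl gives a 16-fold higher number from compound 1 to compound 3 (1.21 log units; beyond the scatter), so the group that had marked the longer half-life among the earlier compounds no longer does, and compound 3 lasts longest of the three shown. The first of these steps has an open end, and compound 2 is held at a limit of the assay and not at a number: the limit of < 0.0334 h in this assay, at which 1 of the 3 values shown sits.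

The compounds shown leave open how the half-life responds to other groups at this place, such as hydroxy, ethoxy, a primary amine or a longer chain, and so whether methoxy is unusual there or one of many groups that last as long. They also leave open the exact size of the step from dimethylamino to methoxy, and whether the same change gives a similar step on another core.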